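Methoxy on the Benzyl Ring of an Oxime Ether Series

The source may report more compounds than this note shows. Statements on the series, on what has been measured and on what is new or still open speak of the compounds shown alone.

Measured compounds:
compound 1, `COc1ccc(CO/N=C/c2c(-c3ccc4ccccc4c3)nc3occn23)cc1`, 4400 nM
compound 2, `C(=N/OCc1ccccc1)\c1c(-c2ccc3ccccc3c2)nc2occn12`, 840 nM
compound 3, `Clc1ccc(CO/N=C/c2c(-c3ccccc3)nc3sccn23)cc1Cl`, 580 nM

These three compounds were measured in an assay on HepG2 cells for agonist activity at nuclear receptor subfamily 1 group I member 3 (Homo sapiens), read by a luciferase reporter, with a stated time of 23 h; on this read-out higher numbers stand for an effect only at larger amounts of compound and lower numbers for an effect already at smaller amounts. Compound 2 and compound 1 differ in one place: methoxy in place of hydrogen on an aromatic carbon. That change gave a 5.2-fold higher number from compound 2 to compound 1 (0.72 log units; beyond the scatter). Compound 3 has a different core from compound 2; the difference between the two cores is not broken down here, and the two values lie within the usual scatter of each other.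

Compound 4, `COc1ccc(-c2nc3sccn3c2/C=N/OCc2ccc(Cl)c(Cl)c2)cc1`, has not yet been measured in this assay. It differs from compound 3 in one place: methoxy in place of hydrogen on an aromatic carbon. This is the same change as that from compound 2 to compound 1, made on another core. Because that earlier change gave a 5.2-fold higher number from compound 2 to compound 1 (0.72 log units; beyond the scatter), a step of similar size is expected here, namely a 5.2-fold higher number from compound 3 to compound 4 (0.71 log units; beyond the scatter). Compound 4 is therefore estimated to give about 3000 nM, most likely between 1000 nM and 9000 nM.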

Compound 4, half-maximal effective concentration: 490 nM
Compound 4: the middle estimate sits 6.1-fold (0.79 log units) above what was measured; the whole stated range lies above it.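

On the core of compound 3, the change from phenyl to 4-methoxyphenyl gave a 1.2-fold lower number from compound 3 to compound 4 (0.07 log units; within the scatter) and so did not repeat the larger step seen on the other core. The same kind of change therefore cannot be assumed to carry the same effect from one core to another in this series: the same change on two cores in this assay, a 5.2-fold higher number (0.72 log units; beyond the scatter) from compound 2 to compound 1 and a 1.2-fold lower number (0.07 log units; within the scatter) from compound 3 to compound 4, 6.2-fold (0.79 log units) apart, beyond the scatter of two such steps. What causes this gap is not shown: the two pairs differ in their cores and in the ring that carries the methoxy, the benzyl ring in compound 1 and the phenyl ring in compound 4.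

Two pairs cannot tell which outcome is more typical of the series. On these data alone, it also remains open how an amine or a carboxylic acid would behave in place of the methoxy.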